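A few compounds are considered here, and "the series" means these few. Any claim that something is new, unique, unknown or untested is made for them only; others in the source may bear on it.

Three compounds of this series carry a measurement in a functional assay on HCT-116 cells (Homo sapiens) for inhibition, read by MTT assay, with a stated time of 24 h, tested at 10 uM; on this read-out higher numbers stand for more inhibition of growth at the one concentration tested and lower numbers for less inhibition of growth. Compound 1 `N#Cc1ccc(-c2cnc3[nH]cc(-c4nnc(-c5ccc(F)cc5)o4)c(=O)c3c2)cc1` gives 18.9% in this assay. Compound 2 `CS(=O)(=O)c1ccc(-c2cnc3[nH]cc(-c4nnc(-c5ccncc5)o4)c(=O)c3c2)cc1` gives 7.83% in this assay, and compound 3 `CS(=O)(=O)c1ccc(-c2cnc3[nH]cc(-c4nnc(-c5ccc(Cl)cc5)o4)c(=O)c3c2)cc1` gives 17% in this assay. On these numbers compound 3 stands close to compound 1, the two values lying within the scatter of each other, and the single-point step a number 9.2 percentage points higher from compound 2 to compound 3 (within the scatter) is also within the scatter, so no compound can be set apart as more or less active on what is shown.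

Compound 4 `N#Cc1ccc(-c2cnc3[nH]cc(-c4nnc(-c5ccc(Cl)cc5)o4)c(=O)c3c2)cc1` is not yet measured. Relative to compound 3 the change is cyano in place of methylsulfonyl on an aromatic carbon. Among the measured compounds shown here, no measured step in this assay addresses this change on its own; compound 1 and compound 3 differ in this place but also on the oxadiazole-linked phenyl ring, so their two values can only be noted as lying within the scatter of each other. Within the compounds shown no single change has moved the read-out beyond the scatter. Compound 4 is therefore expected to give about 18% in this assay, with a range of 8% to 28%. The expected step of a number 1 percentage points higher from compound 3 to compound 4 (within the scatter) is estimated to stay within the scatter, with no direction beyond it.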

Compound 4, percent growth inhibition at one concentration: 18.3%
Estimate against measurement, compound 4: 0.3 percentage points below; the measured number falls inside the stated range.
By their numbers in this assay, from the lowest: compounds 2, 3, 4 and 1 (each within the scatter of the next, the first and the last beyond it).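

In this assay, among the compounds shown here, compound 4 gives the first single-place reading of the group on this six-membered aromatic ring of carbon only, para to a large group: with the 4-chlorophenyl on the other side held constant, cyano in place of methylsulfonyl gives a number 1.3 percentage points higher from compound 3 to compound 4 (within the scatter). It also gives a single-place reading on the other aromatic ring, where, with the 4-cyanophenyl held constant, chloro in place of fluoro gives a number 0.6 percentage points lower from compound 1 to compound 4 (within the scatter). Compound 1 and compound 3 differ in two places, and compound 4 now joins them, so each change can be read alone, and neither moves the read-out beyond the scatter at this one concentration.

No data on any property of these compounds bear on either step. It remains open whether a group of another kind at this position, such as a primary amine, a carboxylic acid or a longer alkyl chain, would give a step beyond the scatter, and whether the steps among these compounds would hold at other concentrations or exposure times.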